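Adding an acetamido group to compound 2

The source may report more compounds than this note shows. Statements on the series, on what has been measured and on what is new or still open speak of the compounds shown alone.

Of the compounds shown here, two have so far been tested in an ADME assay on HCT-116 cells (Homo sapiens) for cytotoxicity, read by CellTiter-Glo, with a stated time of 72 h; on this read-out lower numbers stand for stronger inhibition and higher numbers for weaker inhibition. Compound 1 `Cc1cc(C)c(S(=O)(=O)N2CCC(N3CCC(c4ccccc4)CC3)CC2)c(C)c1` gives > 5000 nM, which is a limit of the assay and not a number. Compound 2 `CC1CCN(C2CCN(S(=O)(=O)c3cccc4ccccc34)CC2)CC1` gives > 10000 nM, which is likewise a limit and not a number. Compound 2 therefore has no numerical value of its own, and the only other result available is also a limit. For the measured compounds named here, no step between measured compounds is available to show how large a structural change might be.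

Compound 3 `CC(=O)Nc1ccc(S(=O)(=O)N2CCC(N3CCC(C)CC3)CC2)c2ccccc12` differs from compound 2 by a single change, acetamido in place of hydrogen on an aromatic carbon, para to a large group. Going by the values given here, with no measured step as a guide, no shift beyond the usual scatter is expected in this assay, in either direction. This expectation rests on compound 2 alone, whose > 10000 nM is a limit. The expected change is a number no higher from compound 2 to compound 3 (the limit leaves the size open). For compound 3 the estimated value is 10000 nM, with an expected range of 3000 nM to 30000 nM.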

Compound 3, half-maximal inhibitory concentration: > 10000 nM
Compound 3 gave a limit, no number; the forecaster's own chance of this, stated with the estimate: 75%; the middle value sits exactly at the limit.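

In this assay compound 3 gives > 10000 nM, which is a limit and not a number. For the compounds shown here, compound 2 gives > 10000 nM, likewise a limit, so no step from one to the other can be read. The compounds shown leave open whether acetamido in place of hydrogen on an aromatic carbon changes the value in this assay at all.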